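Benzyl for cyclohexyl on the imidazole nitrogen, second pair

The source may report more compounds than this note shows. Statements on the series, on what has been measured and on what is new or still open speak of the compounds shown alone.

Compound 1 `O=Cc1ccc(-c2cn3ccnc3c(-c3ccc4ncn(C5CCCCC5)c4c3)n2)cc1` and compound 2 `O=Cc1ccc(-c2cn3ccnc3c(-c3ccc4ncn(Cc5ccccc5)c4c3)n2)cc1` share a core bearing an aldehyde-substituted phenyl; in a functional assay on UO-31 cells (Homo sapiens) for inhibition, read by sulforhodamine B assay, with a stated time of 48 h, tested at 10 uM (a lower number here means less inhibition, a higher number more inhibition at the concentration tested (going by the name of the read-out)), compound 1 gives 82.2% and compound 2 gives 82.2%. The change between them, (benzyl in place of cyclohexyl on an aromatic nitrogen), produced no change at the digits printed from compound 1 to compound 2 (within the scatter). Compound 3 `c1cn2cc(-c3ccc4c(c3)ncn4C3CCCCC3)nc(-c3ccc4ncn(C5CCCCC5)c4c3)c2n1` carries a different core; the difference between the two cores is not broken down here. In this assay compound 3 gives 25.6%, the lowest of the three numbers, separated from compound 1 and from compound 2 by gaps beyond the scatter. Compound 4 `c1ccc(Cn2cnc3ccc(-c4nc(-c5ccc6c(c5)ncn6C5CCCCC5)cn5ccnc45)cc32)cc1` has not been measured. It differs from compound 3 by benzyl in place of cyclohexyl on an aromatic nitrogen, the same change as from compound 1 to compound 2, at a place described in identical words. For the measured compounds named here, the step from compound 3 to compound 4 in this assay is expected to be a number 0.4 percentage points higher from compound 3 to compound 4 (within the scatter), because no change at the digits printed from compound 1 to compound 2 (within the scatter) was seen for the one earlier occurrence of this change, with no other pair to test it. Compound 4 is therefore estimated at 26%. For compound 4 the expected range runs from 10% to 45%.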

Compound 4, a percentage reported as inhibition, at one concentration (the size of the read-out at that concentration, not a potency): -51.4%
Estimate against measurement, compound 4: 77.4 percentage points above, and the stated range ends above it.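

In this assay, benzyl in place of cyclohexyl on an aromatic nitrogen does not carry from one core to the other: the new step is a number 77 percentage points lower from compound 3 to compound 4 (beyond the scatter), and the two occurrences of the change disagree: the same change on two cores in this assay, no change at the digits printed (within the scatter) from compound 1 to compound 2 and a number 77 percentage points lower (beyond the scatter) from compound 3 to compound 4, 77 percentage points apart, beyond the scatter of two such steps

For these two pairs, then, the outcome of the change depends on the core that carries it, and a flat result on the core of compound 1 gives no safe guide to the core of compound 3. The two pairs do not show which feature of the cores is responsible, and they do not show what the negative reading of compound 4, -51.4%, means for the cells.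

Open, from the compounds shown here alone, is how other groups on that nitrogen behave on each core, such as a methyl or a longer chain ending in an amine. Also open, going by these compounds, is whether a carboxylic acid or a hydroxymethyl in place of the aldehyde on the phenyl of compound 1 and compound 2 would keep the flat result seen there.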